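A few compounds are considered here, and "the series" means these few. Any claim that something is new, unique, unknown or untested is made for them only; others in the source may bear on it.

Compound 1 `O=C(O)c1ccccc1-c1ccc(CCc2ncc(Cc3ccccc3F)[nH]2)cc1` gives 177 nM in an in vitro functional assay on cells for agonist activity at Bombesin receptor subtype-3 (Homo sapiens), read by luminescence and calcium flux (a higher number here means that more compound is needed for the effect, a lower number that less compound is needed), the lowest of the three numbers in hand; compound 2 `O=C(O)c1ccccc1-c1ccc(CCc2ncc(CC3CCOCC3)[nH]2)cc1` gives 338 nM and compound 3 `O=C(O)c1ccccc1-c1ccc(CCc2ncc(CC3CCC3)[nH]2)cc1` gives 588 nM in this assay. The steps between them read a 1.9-fold higher number from compound 1 to compound 2 (0.28 log units; within the scatter), a 3.3-fold higher number from compound 1 to compound 3 (0.52 log units; beyond the scatter) and a 1.7-fold higher number from compound 2 to compound 3 (0.24 log units; within the scatter).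

Compound 4 `CCCCc1cnc(CCc2ccc(-c3ccccc3C(=O)O)cc2)[nH]1` differs from compound 1 by propyl in place of 2-fluorophenyl on a saturated chain carbon bound to an aromatic carbon. The two steps that bear on it are those from compound 1 to compound 2 and from compound 1 to compound 3, both replacing 2-fluorophenyl at the same place, both giving higher numbers, one beyond the scatter. A higher number for compound 4 is therefore expected, about a 2.8-fold higher number from compound 1 to compound 4 (0.45 log units; beyond the scatter), because of a 3.3-fold higher number from compound 1 to compound 3 (0.52 log units; beyond the scatter). Compound 4 is estimated at 500 nM, within a range of 200 nM to 1300 nM.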

Compound 4, half-maximal effective concentration: 2710 nM
Estimate against measurement, compound 4: 5.4-fold (0.73 log units) below; the whole stated range lies below it.
By their numbers in this assay, from the lowest: compounds 1, 2 and 3 (each within the scatter of the next, the first and the last beyond it); then compound 4.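

In this assay, the open-chain propyl separates from all three ring-bearing groups at this place: a 15-fold higher number from compound 1 to compound 4 (1.18 log units; beyond the scatter), an 8.0-fold higher number from compound 2 to compound 4 (0.90 log units; beyond the scatter) and a 4.6-fold higher number from compound 3 to compound 4 (0.66 log units; beyond the scatter). Among these four compounds, the lower numbers go with a ring in the group, aromatic or saturated, and no compound goes against this, though compound 4 is the only one without a ring. No data on hand explain the step.

As far as these compounds go, whether the ring itself or the size of the group matters stays open. A longer chain such as hexyl, a branched chain such as isobutyl, or a smaller ring such as cyclopropyl could separate the two.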